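Chain length and ring size around the arylpiperazine core

The source may report more compounds than this note shows. Statements on the series, on what has been measured and on what is new or still open speak of the compounds shown alone.

For the measured compounds named here, compound 1 `c1ccc2c(c1)CC2CCCN1CCN(c2cccc3c2OCCO3)CC1` gives 0.45 mg/kg in an assay for activation of Adrenergic receptor alpha-1 (Rattus norvegicus) (a higher number here means that more compound is needed for the effect, a lower number that less compound is needed), the lower of the two numbers measured so far. Compound 2 `c1ccc2c(c1)CC2CCCCN1CCN(c2cccc3c2OCCO3)CC1` gives 7.15 mg/kg in this assay, and the step of a 16-fold higher number from compound 1 to compound 2 (1.20 log units; beyond the scatter) shows a large loss on lengthening the chain by one carbon. Compound 3 `c1ccc2c(c1)CCC2CCN1CCN(c2cccc3c2OCCO3)CC1` differs from compound 1 as follows: a group of 9 heavy atoms (9 carbon; one five-membered non-aromatic ring of carbon only, one six-membered aromatic ring of carbon only) in place of a group of 9 heavy atoms (9 carbon; one four-membered non-aromatic ring of carbon only, one six-membered aromatic ring of carbon only), on a saturated chain carbon, two bonds along the chain from an amine nitrogen in a ring. Going by the values given here, the only measured step bears on chain length alone, not on the ring, so the rearrangement in compound 3 is expected to cost a modest step of a 2.2-fold higher number from compound 1 to compound 3 (0.35 log units; beyond the scatter). Compound 3 is estimated at 1 mg/kg, with a range from 0.25 mg/kg to 4 mg/kg.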

Compound 3, dose for half-maximal effect: 4.01 mg/kg
Estimate against measurement, compound 3: 4.0-fold (0.60 log units) below; measured number outside the range, above it.
By their numbers in this assay, from the lowest: compound 1; then compounds 3 and 2 (each within the scatter of the next).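

Exchanging the group of compound 1 for 2,3-dihydro-1H-inden-1-yl keeps the same atoms yet gives an 8.9-fold higher number from compound 1 to compound 3 (0.95 log units; beyond the scatter) in this assay. This position therefore responds to how the same atoms are joined, whereas the earlier step, a 16-fold higher number from compound 1 to compound 2 (1.20 log units; beyond the scatter), showed only the cost of adding one carbon. Nothing measured here bears on the reason for the new step.

Still open, on these data alone, is how 2,3-dihydro-1H-inden-1-yl behaves on a longer chain. Also open, as far as these compounds go, is whether a six-membered non-aromatic ring of carbon only, in the same place, would continue this direction.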